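Notes on the series: from compound 2 to compound 3

This account rests on a few compounds, and the source may have more. Where it says the series, first, only, none or still open, it means among the compounds named here.

Measured so far:
compound 1 `O=C1C=CC(OC(C(F)(F)F)C(F)(F)F)N1c1ccc(Cl)cc1` — 1890 nM
compound 2 `CC(C)c1ccc(N2C(=O)C=CC2OCC(F)(F)F)cc1` — 5800 nM

Both compounds were tested in a functional assay on HeLa cells (Homo sapiens) for inhibition; on this read-out lower numbers stand for stronger inhibition and higher numbers for weaker inhibition. Compound 1 gives 1890 nM. Compound 2 gives 5800 nM, the highest of the two numbers; its gap to compound 1 lies beyond the scatter. Compound 1 and compound 2 differ in more than one place, so no single structural change can be read from that gap.

Compound 3 `COC(=O)c1ccc(N2C(=O)C=CC2OCC(F)(F)F)cc1` keeps the core of compound 2 and differs from it by methoxycarbonyl in place of isopropyl on an aromatic carbon. Going by the values given here, no measured pair carries this change, so nothing is known about its step size. The step of a 1.5-fold lower number from compound 2 to compound 3 (0.16 log units; within the scatter) is expected to be small, toward a somewhat lower number, not clearly beyond the scatter. Compound 3 is therefore expected to give about 4000 nM in this assay, with a range from 1500 nM to 11000 nM.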

Compound 3, half-maximal inhibitory concentration: 5700 nM
For compound 3 the middle estimate is 1.4-fold (0.15 log units) below the measured one, within the range that was stated.
By their numbers in this assay, from the lowest: compound 1; then compounds 3 and 2 (each within the scatter of the next).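

In this assay, going by these compounds alone, the first reading of methoxycarbonyl in place of isopropyl on an aromatic carbon is a 1.0-fold lower number from compound 2 to compound 3 (0.01 log units; within the scatter), so this change leaves the read-out within the scatter. At this place, para to a large group, the entering group has one more heavy atom than the leaving one, has two hydrogen-bond acceptors where the leaving group has none, and still does not separate the two compounds. The data shown offer no measurement that would account for this result.

On these data alone, whether an amine, a carboxylic acid or a longer chain at this place would also stay within the scatter of compound 2 remains open. Compound 1 differs from compound 3 in more than one place, so the separate contribution of each of those differences also remains unresolved.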